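Swapping a branched chain for a short alkyne

The source may report more compounds than this note shows. Statements on the series, on what has been measured and on what is new or still open speak of the compounds shown alone.

Measured so far:
compound 1 `COc1cc(Cc2nc3c(N)nc(F)nc3n2CC2CCCO2)cc(OC)c1OC` – 22900 nM
compound 2 `CCC(CC)Cn1c(Cc2cc(OC)c(OC)c(OC)c2)nc2c(N)ncnc21` – 158000 nM
compound 3 `CC[C@H](C)Cn1c(Cc2cc(OC)c(OC)c(OC)c2)nc2c(N)nc(F)nc21` – 43700 nM

Three compounds share a core and a trimethoxybenzyl group and differ in the chain on the aromatic nitrogen. In a functional assay on MCF7 cells (Homo sapiens) for antiproliferative activity (a lower number here means a stronger inhibitor, a higher number a weaker inhibitor), compound 2 gives 158000 nM, the highest number of the three: compound 3 sits closest to it, with 43700 nM, and compound 1 furthest, with 22900 nM; both gaps lie beyond the scatter.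

Compound 4 `C#CCCCn1c(Cc2cc(OC)c(OC)c(OC)c2)nc2c(N)ncnc21` has not been measured. It differs from compound 2 by but-3-yn-1-yl in place of pentan-3-yl on a saturated chain carbon bound to an aromatic nitrogen.

Among the compounds with values here, the only measured step at this same place is a 1.9-fold higher number from compound 1 to compound 3 (0.28 log units; within the scatter), which stayed within the scatter, although it was made on a core that also carries a fluorine. Within the data shown here, that is the sole guide, and it suggests that changing the chain on the nitrogen moves the number little. For compound 4 the expected step is therefore a 1.6-fold lower number from compound 2 to compound 4 (0.20 log units; within the scatter), a modest drop at most, not clearly beyond the scatter. The estimate for compound 4 is 100000 nM, with a range from 30000 nM to 350000 nM.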

Compound 4, half-maximal inhibitory concentration: 24000 nM
Beside the measured number, compound 4's estimate is 4.2-fold (0.62 log units) above it, and the stated range ends above it.
By their numbers in this assay, from the lowest: compounds 1, 4 and 3 (each within the scatter of the next); then compound 2.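

In this assay, the chain on the saturated carbon bound to the aromatic nitrogen proves able to shift the number well beyond the scatter: but-3-yn-1-yl in place of pentan-3-yl gives a 6.6-fold lower number from compound 2 to compound 4 (0.82 log units; beyond the scatter). The earlier step at this place, a 1.9-fold higher number from compound 1 to compound 3 (0.28 log units; within the scatter), stayed within the scatter and was made on the core carrying fluorine, so a small change there does not hold for every pair of chains or for both cores. No measurement shown gives an explanation for the drop.

This single step swaps a branched chain for an unbranched one ending in a triple bond, so it cannot separate those two features. A plain butyl chain would test whether the triple bond is needed, and but-3-yn-1-yl on the fluorinated core would test whether the step carries over.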